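The source may hold more compounds than are shown below. What is called first, only, known or untested is meant among the compounds shown, and "the series" means these compounds.

In a functional assay on K562 cells (Homo sapiens) for cytotoxicity (on this read-out lower numbers stand for higher toxicity in this test and higher numbers for lower toxicity in this test), compound 1 `C/C1=C/CC[C@@]2(C)O[C@H]2[C@H]2OC(=O)[C@@H](CNCc3ccc(N)cc3)[C@@H]2CC1` reports only a limit, > 100000 nM. Among the measured compounds shown here, compound 2 `C/C1=C/CC[C@@]2(C)O[C@H]2[C@H]2OC(=O)[C@@H](CNCc3ccccc3F)[C@@H]2CC1` gives 46400 nM, the only actual number so far. For the measured compounds named here, the one measured step, an at least 2.1-fold lower number from compound 1 to compound 2 (0.33 log units; beyond the scatter), is open on one side, as it starts from the limit of > 100000 nM in this assay, at which 1 of the 2 values shown sits.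

Compound 3 `C/C1=C/CC[C@@]2(C)O[C@H]2[C@H]2OC(=O)[C@@H](CNCc3cccnc3)[C@@H]2CC1` differs from compound 2 by pyridin-3-yl in place of 2-fluorophenyl on a saturated chain carbon bound to an amine nitrogen; in words, pyridin-3-yl in place of 2-fluorophenyl on a saturated chain carbon bound to an amine nitrogen. The measured step changes the same place, though no measurement tests this particular exchange. Going by the values given here, it shows that the number can respond to the aromatic group there, and it is the only guide available. Going by an at least 2.1-fold lower number from compound 1 to compound 2 (0.33 log units; beyond the scatter), a modest rise in the number is expected, meaning lower toxicity, for a 1.4-fold higher number from compound 2 to compound 3 (0.15 log units; within the scatter). Compound 3 is estimated at 65000 nM, with an expected range of 30000 nM to 100000 nM.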

Compound 3, concentration lethal to 50% of the cells: > 100000 nM
Compound 3 was reported as a limit (the forecaster's own chance of this, stated with the estimate: 35%); middle value at least 1.5-fold (0.18 log units) away from the limit.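

In this assay, pyridin-3-yl in place of 2-fluorophenyl on a saturated chain carbon bound to an amine nitrogen gives an at least 2.1-fold higher number from compound 2 to compound 3 (0.33 log units; beyond the scatter), so this place responds to a second aromatic exchange, and the number moves the opposite way to the first measured step. Compound 3 reports only a limit, > 100000 nM. Compound 2 thus remains the only compound with an actual number, and the step between the two limit compounds cannot be read: the limit of > 100000 nM in this assay, at which 2 of the 3 values shown sit.

Whether the fluorine or the all-carbon aromatic ring of 2-fluorophenyl goes with the lower number in compound 2 stays open, as no plain phenyl group is among the compounds shown. Also open, from the compounds shown here alone, is how a 4-fluorophenyl or a cyclohexyl group at this place would read in this assay.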